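The source may report more compounds than this note shows. Statements on the series, on what has been measured and on what is new or still open speak of the compounds shown alone.

Measured compounds:
compound 1, `CCN(C(=O)c1cc([N+](=O)[O-])ccc1Oc1ccc(OC)cc1)c1ccc(Cl)cc1`, 8300 nM;
compound 2, `COc1ccc(Oc2ccc([N+](=O)[O-])cc2C(=O)Nc2ccc(Cl)cc2)cc1`, 10100 nM;
compound 3, `COc1ccc(NC(=O)c2cc(C#N)ccc2Oc2ccc(OC)cc2)cc1`, 2500 nM.

In a functional assay (Homo sapiens) for inhibition, using a membrane potential dye, in the presence of a further agent that is not named here (a higher number here means a weaker inhibitor, a lower number a stronger inhibitor), compound 2 gives the highest of the three numbers. Its nearest neighbour is compound 1, and the step of a 1.2-fold higher number from compound 1 to compound 2 (0.09 log units; within the scatter) lies within the scatter, so the two cannot be ordered. For the measured compounds named here, compound 3 stands furthest away, with a number lower than that of compound 2 by a gap that is beyond the scatter; no single-point step is drawn between them, since they differ in more than one place.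

Compound 4, `COc1ccc(Oc2ccc([N+](=O)[O-])cc2C(=O)Nc2ccc(S(N)(=O)=O)cc2)cc1`, is not yet measured. It differs from compound 2 by sulfamoyl in place of chloro on an aromatic carbon. Going by the values given here, none of the measured steps touches this position: the only measured step, a 1.2-fold higher number from compound 1 to compound 2 (0.09 log units; within the scatter), concerns the amide-type nitrogen and was within the scatter. There is thus no measured basis for the direction of the change, and the expectation rests on the value of compound 2 alone. Compound 4 is therefore expected to lie near compound 2, with a wide range, the estimated step being a 1.5-fold higher number from compound 2 to compound 4 (0.17 log units; within the scatter). For compound 4 the estimate in this assay is 15000 nM, between 4000 nM and 60000 nM.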

Compound 4, half-maximal inhibitory concentration: 1800 nM
Beside the measured number, compound 4's estimate is 8.3-fold (0.92 log units) above it; the whole stated range lies above it.
By their numbers in this assay, from the lowest: compounds 4 and 3 (each within the scatter of the next); then compounds 1 and 2 (each within the scatter of the next).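

In this assay the change from 4-chlorophenyl to 4-sulfamoylphenyl gives a 5.6-fold lower number from compound 2 to compound 4 (0.75 log units; beyond the scatter) and so marks this place, on an aromatic carbon para to a large group, as one where the number moves beyond the scatter. The only earlier step, a 1.2-fold higher number from compound 1 to compound 2 (0.09 log units; within the scatter) at the amide-type nitrogen, had shown no such movement and said nothing about this place. This single pair shows that the exchange of chloro for sulfamoyl gives a stronger inhibitor in this assay, but nothing at hand accounts for the step.

Going by these compounds, it remains open whether the sulfamoyl group is specifically needed here or whether a carboxylic acid, a methylsulfonyl group or an amine at the same place would give a similar number. Also open, on these data alone, is whether the same exchange would carry over to the ethyl-bearing amide of compound 1.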